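Methoxy on the pendant phenyl: compound 4 from compound 3

This account rests on a few compounds, and the source may have more. Where it says the series, first, only, none or still open, it means among the compounds named here.

Measured compounds:
Compound 1 `COc1ccc(-c2cc(C(=O)Nc3ccc(Oc4ccnc5cc(OCCCN6CCCCC6)c(OC)cc45)c(F)c3)c3ccccc3n2)cc1` — 210 nM
Compound 2 `COc1cc2c(Oc3ccc(NC(=O)c4cc(-c5cccc(Cl)c5)nc5ccccc45)cc3F)ccnc2cc1OCCCN1CCC(C)CC1` — 30 nM
Compound 3 `COc1cc2c(Oc3ccc(NC(=O)c4cc(-c5ccccc5)nc5ccccc45)cc3F)ccnc2cc1OCCCN1CCC(C)CC1` — 19 nM

In a functional assay on MKN-45 cells (Homo sapiens) for cytotoxicity, read by MTT assay, with a stated time of 72 h (a higher number here means a weaker inhibitor, a lower number a stronger inhibitor), compound 3 gives the lowest number of the three; compound 2 sits nearest, and in this assay compound 1 gives a much higher number, a gap that lies beyond the scatter. Compound 4 `COc1ccc(-c2cc(C(=O)Nc3ccc(Oc4ccnc5cc(OCCCN6CCC(C)CC6)c(OC)cc45)c(F)c3)c3ccccc3n2)cc1` is compound 3 with methoxy in place of hydrogen on an aromatic carbon.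

Among the measured compounds shown here, only one single-point step is available, a 1.6-fold lower number from compound 2 to compound 3 (0.20 log units; within the scatter), and it concerns a different substituent on the same ring; it lies within the scatter and on its own would suggest a small effect of ring substitution. For the measured compounds named here, compound 1 carries the methoxy of compound 4 but also a different amine on the side chain, so no single step separates it from compound 3; its values and those of compound 3 show only that the pair of changes together goes with a much higher number, and which change carries that cannot be told.

Compound 4 is therefore expected to lie between compound 3 and compound 1, with an estimated step of a 2.9-fold higher number from compound 3 to compound 4 (0.46 log units; beyond the scatter) toward a higher number in this assay. The estimate for compound 4 is 55 nM, with a range from 15 nM to 210 nM.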

Compound 4, half-maximal inhibitory concentration: 320 nM
Beside the measured number, compound 4's estimate is 5.8-fold (0.76 log units) below it; the measured number lies above the stated range.
By their numbers in this assay, from the lowest: compounds 3 and 2 (each within the scatter of the next); then compounds 1 and 4 (each within the scatter of the next).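

In this assay, among the compounds shown here, the single change from phenyl to 4-methoxyphenyl gives a 17-fold higher number from compound 3 to compound 4 (1.23 log units; beyond the scatter), so this one group, para to a large group on the pendant ring, is enough for a large loss with the side chain held constant. The step from chloro to hydrogen had suggested that substitution on this ring matters little, but an 11-fold higher number from compound 2 to compound 4 (1.03 log units; beyond the scatter) shows that this does not hold for every substituent, although that step alters both the group and its place on the ring. With the 4-methoxyphenyl in place, the added methyl on the saturated ring gives a 1.5-fold higher number from compound 1 to compound 4 (0.18 log units; within the scatter) and stays within the scatter, so the side-chain difference between these two compounds is not seen in this assay.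

No measurement here explains why methoxy has this effect. On these data alone, it stays open whether fluoro, hydroxyl or a dimethylamino group para to the large group would give a number like that of compound 3 or like that of compound 4, and so whether the loss is particular to methoxy or comes with any group at this place.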